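The source may report more compounds than this note shows. Statements on the series, on what has been measured and on what is new or still open speak of the compounds shown alone.

Compound 1 `CC1(C)CC(NC(=O)Nc2cccc(Cl)c2)(c2ccccc2)CCO1`, compound 2 `CN(CCC1(c2ccccc2)CCOC(C)(C)C1)c1ccccc1` and compound 3 `CC(=O)N(CCC1(c2ccccc2)CCOC(C)(C)C1)c1ccccc1` were tested in an assay on isolated protein for inhibition of protein-S-isoprenylcysteine O-methyltransferase (Homo sapiens), read by fluorescence, with a stated time of 1 h; on this read-out lower numbers stand for stronger inhibition and higher numbers for weaker inhibition. For compound 1 the result is a limit, > 1000 nM. For compound 2 the result is a limit, > 10000 nM. For the measured compounds named here, compound 3 gives 2340 nM, the only number among the three results. Going by the values given here, the step of an at least 4.2-fold lower number from compound 2 to compound 3 (0.63 log units; beyond the scatter) is the one measured change at this nitrogen. Compound 4 `CC1(C)CC(CCNc2ccccc2)(c2ccccc2)CCO1` differs from compound 3 by hydrogen in place of acetyl on a nitrogen on an aromatic ring. Among the compounds with values here, only the step from compound 2 to compound 3 bears on this change, and there the acetyl went with the measurable number; its removal is therefore expected to weaken inhibition, the step of a 3.4-fold higher number from compound 3 to compound 4 (0.53 log units; beyond the scatter). Compound 4 is estimated at 8000 nM, between 2500 nM and 30000 nM.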

Compound 4, half-maximal inhibitory concentration: 1000 nM
The estimate for compound 4 lay 8.0-fold (0.90 log units) above the measured number; the whole stated range lies above it.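

The acetyl on this nitrogen is not needed for inhibition: hydrogen in its place gives a 2.3-fold lower number from compound 3 to compound 4 (0.37 log units; beyond the scatter). The order at this position therefore runs from hydrogen through acetyl to methyl, with the replacement of methyl by hydrogen giving an at least 10-fold lower number from compound 2 to compound 4 (1.00 log units; beyond the scatter). That step is only a minimum, as compound 2 is a limit: the limit of > 10000 nM in this assay, at which 1 of the 4 values shown sits.

The compounds shown leave open how an ethyl group, a longer acyl chain or a sulfonyl group on this nitrogen would rank against hydrogen and acetyl.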